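The source may hold more compounds than are shown below. What is called first, only, known or untested is meant among the compounds shown, and "the series" means these compounds.

Measured compounds in a functional assay on PC-3 cells (Homo sapiens) for antiproliferative activity, read by CCK-8 assay, with a stated time of 6 days; a lower number here means a stronger inhibitor, a higher number a weaker inhibitor:
- compound 1 `N#Cc1ccc(N2CCc3cc(-c4cccnc4)ccc32)cc1C(F)(F)F`: "not determined" (no result reported).
- compound 2 `CCN(c1ccc(C#N)c(Cl)c1)c1cc(-c2ccco2)ccc1C`: > 30000 nM.
- compound 3 `N#Cc1ccc(N2CCc3cc(-c4cccnc4)ccc3C2)cc1C(F)(F)F`: "not determined" (no result reported).

Among the compounds with values here, compound 1 and compound 3 carry no result in this assay, so the only entry that carries information is compound 2. In this assay compound 2 reaches only a limit of the assay, > 30000 nM, and no single number. Of the three entries shown, one sits at that limit (the limit of > 30000 nM in this assay, at which 1 of the 3 values shown sits) and the other two have no number at all, so compound 2 cannot be placed above or below any other compound here.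

Compound 4 `CCN(c1ccc(C#N)c(Cl)c1)c1cc(-c2ccoc2)ccc1C` has not yet been measured in this assay. It keeps the same atoms as compound 2, joined differently: furan-3-yl in place of furan-2-yl on an aromatic carbon. The furan ring stays a five-membered aromatic ring with one hetero atom, one hydrogen-bond acceptor and no net charge; only its point of attachment moves, from furan-2-yl to furan-3-yl.

Within the data shown here, no step between measured compounds exists, so the size of the move from compound 2 to compound 4 cannot be read from data. The expectation is for no change beyond the usual scatter, and most likely a further limit rather than a number. The step from compound 2 to compound 4 is estimated as a step that the limit leaves unreadable from compound 2 to compound 4. For compound 4 the estimate in this assay is 35000 nM, with a range from 10000 nM to 120000 nM.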

Compound 4, half-maximal inhibitory concentration: > 30000 nM
Compound 4 ended at the assay's limit; the forecaster's own chance of this, stated with the estimate: 85%; the middle value lies beyond the limit too.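

In this assay compound 2 and compound 4 both sit at a limit of the assay rather than at a number, so no step can be read for furan-3-yl in place of furan-2-yl: the limit of > 30000 nM in this assay, at which 2 of the 4 values shown sit.

The compounds shown leave open how the two furan attachments compare, and which change to the shared core would give a single number.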